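This account rests on a few compounds, and the source may have more. Where it says the series, first, only, none or still open, it means among the compounds named here.

Of the compounds shown here, three have so far been measured in a functional assay on A2780 cells (Homo sapiens) for antiproliferative activity, read by MTT assay, with a stated time of 48 h; on this read-out higher numbers stand for weaker inhibition and lower numbers for stronger inhibition. Compound 1 `CCNCC(=O)Nc1cc(OC)ccc1C(=O)c1ccc(OC)c2c1C=CC(C)(C)O2` gives 4090 nM in this assay, and compound 2 `COc1ccc(C(=O)c2ccc(OC)c3c2C=CC(C)(C)O3)c(NC(=O)CN(C)C)c1` gives 3990 nM. These two differ in one place only, namely (dimethylamino in place of ethylamino on a saturated chain carbon bound to a carbonyl carbon), and the step of a 1.0-fold lower number from compound 1 to compound 2 (0.01 log units; within the scatter) shows that this exchange did not move the number beyond the usual scatter of the measurement.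

Compound 3 `C=C(c1ccc(OC)cc1NC(=O)CNCC)c1ccc(OC)c2c1OC(C)(C)C=C2` is built on a different core, and the difference between its core and the core of compound 1 is not broken down here. In this assay compound 3 gives 1030 nM, the lowest of the three numbers, with compound 2 and compound 1 each giving a number that is higher by more than the usual scatter.

Compound 4 `C=C(c1ccc(OC)cc1NC(=O)CN(C)C)c1ccc(OC)c2c1OC(C)(C)C=C2` has not yet been measured. It stands to compound 3 as compound 2 stands to compound 1: the change is dimethylamino in place of ethylamino on a saturated chain carbon bound to a carbonyl carbon, the same change in the same place. Because the step of a 1.0-fold lower number from compound 1 to compound 2 (0.01 log units; within the scatter) stayed within the scatter on the core of compound 1, the expectation is that the same change on the core of compound 3 will also leave the number close to where it was, so the step of a 1.0-fold higher number from compound 3 to compound 4 (0.01 log units; within the scatter) is estimated to be small. Compound 4 is therefore expected to give about 1050 nM in this assay, with a likely range from 500 nM to 2200 nM.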

Compound 4, half-maximal inhibitory concentration: 420 nM
Beside the measured number, compound 4's estimate is 2.5-fold (0.40 log units) above it, and the stated range ends above it.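

In this assay, putting dimethylamino in place of ethylamino gives a 2.5-fold lower number from compound 3 to compound 4 (0.39 log units; beyond the scatter) on the core of compound 3, a modest step beyond the scatter, while the same change gives a 1.0-fold lower number from compound 1 to compound 2 (0.01 log units; within the scatter) on the core of compound 1, a step within the scatter. Read alone, these steps might suggest that the change matters on one core and not on the other, but when the two are set side by side, the gap is too small to tell them apart: the same change on two cores in this assay, a 1.0-fold lower number (0.01 log units; within the scatter) from compound 1 to compound 2 and a 2.5-fold lower number (0.39 log units; beyond the scatter) from compound 3 to compound 4, 2.4-fold (0.38 log units) apart, within the scatter of two such steps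

This shows that the pair of steps is compatible with the change carrying from one core to the other, and it gives no firm sign that the core alters the outcome. Among these compounds, only two matched pairs are available. They do not prove that the change acts alike on both cores, and they do not explain why the number moved beyond the scatter in one pair alone.

The compounds shown leave open whether the same holds on further cores and how far the result extends to other amines in this place, such as diethylamino, pyrrolidine or morpholine. They also leave open what a primary amine, a carboxylic acid or a longer chain would do here.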